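The source may hold more compounds than are shown below. What is called first, only, known or untested is meant among the compounds shown, and "the series" means these compounds.

Working notes on the series. In an assay on isolated protein for inhibition of NUAK family SNF1-like kinase 2 (Homo sapiens), read by ADP-Glo, with a stated time of 60 min, tested at 10 uM, in the presence of a further agent that is not named here (on this read-out lower numbers stand for less inhibition and higher numbers for more inhibition at the one concentration tested (going by the name of the read-out)), compound 1 `CCC(=O)Nc1cccc(Oc2nc(Nc3ccc(N(C)C)cc3OC)ncc2Cl)c1` gives 15%, the lowest of the two numbers in hand. Compound 3 `CCC(=O)Nc1cccc(Oc2nc(Nc3ccc(N(C)C)cc3)ncc2Cl)c1` gives 31.7% in this assay, and the step of a number 16.7 percentage points higher from compound 1 to compound 3 (beyond the scatter) goes with hydrogen in place of methoxy on an aromatic carbon. Compound 2 `CCCN(CCC)c1ccc(Nc2ncc(Cl)c(Oc3cccc(NC(=O)CC)c3)n2)cc1`, which carries dipropylamino and lacks the methoxy, is reported in this assay as "not active" (no number reported), without a number.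

Compound 4 `CCC(=O)Nc1cccc(Oc2nc(Nc3ccc(N4CCC(OC)CC4)cc3OC)ncc2Cl)c1` differs from compound 1 by 4-methoxypiperidin-1-yl in place of dimethylamino on an aromatic carbon. Among the measured compounds shown here, no measured step bears directly on this change: the one measured step concerns the methoxy, not the group that is exchanged here. What compound 2 and compound 3 show is that compound 2, with a larger group in that region, is reported as "not active" (no number reported), while compound 3, which carries dimethylamino, gives 31.7%. On that basis the expected step of a number 6 percentage points lower from compound 1 to compound 4 (within the scatter) is downward or at most within the scatter. Compound 4 is therefore estimated at 9%, with a range from 0% to 22% in this assay.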

Compound 4, a percentage reported as inhibition, at one concentration (the size of the read-out at that concentration, not a potency): "not active" (no number reported)
For compound 4 the study gives words and no number; there is nothing to compare the estimate with.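

In this assay, among the compounds shown here, compound 4 gives "not active" (no number reported), so no step from compound 1 to compound 4 can be read. No measurement shown bears on this result. The compounds shown leave open whether 4-methoxypiperidin-1-yl in place of dimethylamino gives any measurable inhibition at all.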